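The source may hold more compounds than are shown below. What is called first, only, known or untested is meant among the compounds shown, and "the series" means these compounds.

Measured so far:
- compound 1, `C=CCCS(=O)(=O)N[C@@H](C(=O)N[C@@H](CC(C)C)C(=O)NCc1c(CC=C)[nH]c2ccc(Cl)cc12)C1CCCCC1` — 1160 nM
- compound 2, `CC(C)C[C@@H]1NC(=O)[C@@H](C2CCCCC2)NC(=O)CCCCCc2[nH]c3ccc(Cl)cc3c2CNC1=O` — 10000 nM

In an assay on isolated protein for inhibition of Trypsin (Homo sapiens) (a lower number here means a stronger inhibitor, a higher number a weaker inhibitor), compound 1 gives 1160 nM, while compound 2, the macrocyclic analogue, gives 10000 nM. Within the data shown here, compound 2 therefore stands as the higher of the two numbers, and its gap to compound 1 lies beyond the scatter of repeated measurements; no single-point step between these two is tabulated, so only the two values themselves can be compared.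

Compound 3, `CC(C)C[C@@H]1NC(=O)[C@@H](C2CCCCC2)NC(=O)[C@H](c2ccccc2)CCCCc2[nH]c3ccc(Cl)cc3c2CNC1=O`, keeps the core of compound 2 and differs from it in one place: phenyl in place of hydrogen on a saturated ring carbon. Among the measured compounds shown here, no measured pair shows what such a change does in this assay, so the expectation rests on compound 2 alone. The step from compound 2 to compound 3 is expected to be small, a 1.4-fold lower number from compound 2 to compound 3 (0.15 log units; within the scatter), and may well fall within the scatter in either direction. For compound 3 the estimate in this assay is 7000 nM, with a range from 2000 nM to 20000 nM.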

Compound 3, half-maximal inhibitory concentration: 2310 nM
Beside the measured number, compound 3's estimate is 3.0-fold (0.48 log units) above it; low and high end bracket the measured number.
By their numbers in this assay, from the lowest: compounds 1 and 3 (each within the scatter of the next); then compound 2.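

In this assay, among these compounds, phenyl in place of hydrogen on this saturated ring carbon of the 16-membered ring gives a 4.3-fold lower number from compound 2 to compound 3 (0.64 log units; beyond the scatter), the first single-place step. The position, two ring bonds from the ring nitrogen, therefore responds to substitution: adding a six-membered aromatic ring with no hydrogen-bond donors or acceptors and no net charge moves the number beyond the scatter, towards a stronger inhibitor. No available data explain this modest gain.

Open, going by these compounds, is whether a smaller methyl group, a benzyl group or a substituted phenyl such as chlorophenyl at this carbon would give a step of similar size. Also open, on these data alone, is how an amine or a carboxylic acid at the same carbon would behave in this assay.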